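The source may hold more compounds than are shown below. What is called first, only, known or untested is meant among the compounds shown, and "the series" means these compounds.

Compound 1 (`CCCCNc1nc(N)nc2ccc(F)cc12`) stands in an ADME assay on HEK293 cells (Homo sapiens) for cytotoxicity, with a stated time of 6 h (a lower number here means that less compound is tolerated, a higher number that more compound is tolerated), at > 18000 nM as a limit of the assay and not a number. Compound 2 (`CCCCNc1nc(N)nc2ccc(OC)cc12`) gives > 18000 nM as a limit too. Going by the values given here, the only measured evidence is therefore the limit of > 18000 nM in this assay, at which 2 of the 2 values shown sit, and no exact value anchors the comparison. Compound 3 (`CCCCNc1nc(N)nc2cc(F)c(F)cc12`) differs from compound 1 by one change: fluoro in place of hydrogen on an aromatic carbon with the new fluoro group ortho to a fluoro group. Among the compounds with values here, no measured step shows this same change. The nearest one is a step that the two limits leave unreadable from compound 1 to compound 2 with methoxy in place of fluoro on an aromatic carbon at the same kind of ring carbon, and it offers no size to carry over. With compound 1 and compound 2 both reported only as limits, no step beyond the scatter is expected in this assay and no direction can be favoured. The step expected is a step that the limit leaves unreadable from compound 1 to compound 3 and it remains an estimate measured against a limit. For compound 3 the estimated value is 25000 nM within an expected range from 12000 nM to 60000 nM and a further limit is the likeliest report.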

Compound 3, half-maximal cytotoxic concentration: > 18000 nM
Compound 3: no number, only a limit; the forecaster's own chance of this, stated with the estimate: 80%; the middle value does not contradict the limit.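

In this assay compound 3 gives > 18000 nM, a limit of the assay and not a number, so no step can be read between compound 1 and compound 3. The compounds shown leave open the concentration at which compound 1, compound 2 or compound 3 would reach a half-maximal cytotoxic effect, with only this to go on: the limit of > 18000 nM in this assay, at which 3 of the 3 values shown sit.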